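Turning two stereocentres on the longest-lasting compound

A few compounds are considered here, and "the series" means these few. Any claim that something is new, unique, unknown or untested is made for them only; others in the source may bear on it.

Measured so far in an ADME assay on the whole organism (strain 129/SvEvBrd x C57BL/6) for metabolic stability, with Mus musculus as the target; a higher number here means that the compound lasts longer, a lower number that the compound disappears faster:
- Compound 1 `CC(F)(F)c1nc([C@@H](O)[C@H](O)[C@H](O)CO)c[nH]1` gives 1 h
- Compound 2 `OC[C@@H](O)[C@@H](O)[C@H](O)c1c[nH]c(-c2cnccn2)n1` gives 1.9 h
- Compound 3 `CC(=O)c1nc([C@@H](O)[C@@H](O)[C@H](O)CO)c[nH]1` gives 5.4 h

Compound 3 holds the highest number of the three, and its gaps to compound 2 and to compound 1 both lie beyond the scatter of repeated measurements. The next structure is compound 4 `CC(=O)c1nc([C@H](O)[C@@H](O)[C@@H](O)CO)c[nH]1`, which has the same atoms and bonds as compound 3 and differs only in configuration as drawn, that is, in how groups on the chain point in space. The change reads: the two compounds have the same atoms and bonds and differ only in configuration as drawn: 2 of 3 stereo elements differ; a stereocentre at a saturated chain carbon is drawn R in compound 3 and S in compound 4; a stereocentre at a saturated chain carbon is drawn R in compound 3 and S in compound 4.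

Within the data shown here, only one measured step is available, a 1.9-fold higher number from compound 1 to compound 2 (0.28 log units; within the scatter), and it lies within the scatter. It places pyrazin-2-yl in place of 1,1-difluoroethyl on an aromatic carbon, so it is a change of group and not of configuration. Among the measured compounds shown here, no measured pair shows what a change of configuration alone does, and the direction is therefore open. Compound 3 (5.4 h) stands at the high end of this small set, which makes a slight fall the more cautious guess. In this assay the expected step is a 1.4-fold lower number from compound 3 to compound 4 (0.13 log units; within the scatter), so no change beyond the scatter is expected. For compound 4 the estimate is 4 h, with an expected range from 1.5 h to 9 h.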

Compound 4, half-life: 6 h
Compound 4: middle estimate off by 1.5-fold (0.18 log units), on the low side, and the stated range covers the measured number.
By their numbers in this assay, from the lowest: compounds 1 and 2 (each within the scatter of the next); then compounds 3 and 4 (each within the scatter of the next).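

In this assay the result is a 1.1-fold higher number from compound 3 to compound 4 (0.05 log units; within the scatter), so turning two stereocentres on the chain gives no difference that can be told apart from the scatter of repeated measurements. Among these compounds, this is the first pair in the set that tests configuration alone, as the earlier step between compound 1 and compound 2 exchanged one group for another. The step can be read as a pure test of configuration because nothing else separates the two structures: the fact that compounds 3 and 4 differ only in the configuration as drawn

Still open, as far as these compounds go, is whether the third stereo element, the one drawn the same in compound 3 and compound 4, would behave in the same way, and whether turning either of the other two stereocentres on its own would also give a step within the scatter. Also open, from the compounds shown here alone, is whether configuration would count for as little with a carboxylic acid or an amine on the aromatic carbon, or with a methyl ether in place of a hydroxyl group on the chain.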